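Benzylsulfanyl chalcone-type series: removing one chloro on the benzyl

The compounds below may be only part of what the source reports. "The series", "measured", "known", "first", "only" and "open" are said of these compounds alone.

Measured so far:
- compound 1, `COc1ccc(OC)c(/C=C(/SCc2ccc(Cl)c(Cl)c2)C(=O)c2ccc(Cl)cc2)c1`, 10000 nM
- compound 2, `CN(C)c1ccc(/C=C(/SCc2ccc(Cl)c(Cl)c2)C(=O)c2ccc(Cl)cc2)cc1`, 50000 nM

Compound 2 holds the highest number of the two; its nearest neighbour is compound 1, and the step of a 5.0-fold higher number from compound 1 to compound 2 (0.70 log units; beyond the scatter) places the two apart beyond the scatter in a functional assay on DU-145 cells (Homo sapiens) for inhibition, read by trypan blue exclusion, with a stated time of 96 h; on this read-out higher numbers stand for weaker inhibition of growth and lower numbers for stronger inhibition of growth. That step exchanges the aryl group on the double-bonded chain carbon and leaves the benzylsulfanyl arm untouched.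

Compound 3, `CN(C)c1ccc(/C=C(/SCc2ccc(Cl)cc2)C(=O)c2ccc(Cl)cc2)cc1`, keeps the 4-(dimethylamino)phenyl group and the 4-chlorobenzoyl of compound 2 and differs only in the benzylsulfanyl arm: hydrogen in place of chloro on an aromatic carbon. Within the data shown here, no measured pair in this set changes that arm, so nothing among the numbers so far speaks directly to this step. Among the measured compounds shown here, the only measured step, from compound 1 to compound 2, concerns a different part of the molecule and is of modest size; it offers no direction for the present change. The working expectation is therefore a step of no change at the digits printed from compound 2 to compound 3 (within the scatter) that stays within the scatter. On that basis compound 3 is estimated at 50000 nM, with a range from 15000 nM to 160000 nM, and with a real chance that this assay returns only a limit for so weak a compound.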

Compound 3, concentration for 50% growth inhibition: > 100000 nM
Compound 3: a limit, no number; the forecaster's own chance of this, stated with the estimate: 30%; middle value at least 2.0-fold (0.30 log units) from the limit.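

Among these compounds, the first reading on the benzylsulfanyl arm in this assay is an at least 2.0-fold higher number from compound 2 to compound 3 (0.30 log units; that floor lies within the scatter), with hydrogen in place of chloro on an aromatic carbon ortho to a chloro group. Compound 3 gives > 100000 nM, which is a limit of the assay and not a number. With the 4-(dimethylamino)phenyl group and the 4-chlorobenzoyl held fixed, going from (3,4-dichlorobenzyl)sulfanyl to (4-chlorobenzyl)sulfanyl gives no sign of stronger inhibition of growth, but the size of the step stays unfixed and its floor does not clear the scatter, so the weight of this chloro is not settled, with the reading resting on one value at the ceiling: the limit of > 100000 nM in this assay, at which 1 of the 3 values shown sits.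

The compounds shown leave open whether the same exchange reads the same way on the 2,5-dimethoxyphenyl background, where compound 1 gives 10000 nM and a full number might be obtainable on both sides of the step. They also leave open how this aromatic carbon reads with a fluoro, a methoxy or a trifluoromethyl in place of the chloro, and how the arm reads with a phenethyl in place of the benzyl.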